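The source may hold more compounds than are shown below. What is called first, only, known or untested is meant among the compounds shown, and "the series" means these compounds.

Compound 1 `Cc1ccccc1-n1nncc1CN1C(=O)C2(C(C#N)=C(N)Oc3c2c2nc4ccccc4nc2c2ccccc32)c2ccccc21` and compound 2 `CC(=O)Nc1ccc(-n2nncc2CN2C(=O)C3(C(C#N)=C(N)Oc4c3c3nc5ccccc5nc3c3ccccc43)c3ccccc32)cc1` share the same core and differ only in the group on an aromatic nitrogen. In a functional assay on HCT-116 cells (Homo sapiens) for antiproliferative activity, read by MTT assay, with a stated time of 48 h (on this read-out higher numbers stand for weaker inhibition and lower numbers for stronger inhibition), compound 1 reaches only the limit > 50000 nM. In this assay compound 2 also reaches only the limit > 50000 nM. The step that the two limits leave unreadable from compound 1 to compound 2 therefore cannot be sized, as the limit of > 50000 nM in this assay, at which 2 of the 2 values shown sit, shows. Compound 3 `N#CC1=C(N)Oc2c(c3nc4ccccc4nc3c3ccccc23)C12C(=O)N(Cc1cnnn1-c1ccc(S(N)(=O)=O)cc1)c1ccccc12` differs from compound 2 by sulfamoyl in place of acetamido on an aromatic carbon. Going by the values given here, no measured step bears on this change, and the two measured compounds cannot be told apart. The expected step is a step that the limit leaves unreadable from compound 2 to compound 3, none beyond the scatter. Compound 3 is thus estimated at 60000 nM, within 20000 nM to 200000 nM, most likely again a limit.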

Compound 3, half-maximal inhibitory concentration: 31200 nM
The estimate for compound 3 lay 1.9-fold (0.28 log units) above the measured number; measured number inside the range.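

In this assay compound 3 gives 31200 nM as a real number, which makes 4-sulfamoylphenyl the one group shown on this nitrogen with a readable value. The result is an at least 1.6-fold lower number from compound 2 to compound 3 (0.20 log units; that floor lies within the scatter) for sulfamoyl in place of acetamido, and an at least 1.6-fold lower number from compound 1 to compound 3 (0.20 log units; that floor lies within the scatter) for 4-sulfamoylphenyl in place of 2-methylphenyl. Both steps remain floors, not full sizes: the limit of > 50000 nM in this assay, at which 2 of the 3 values shown sit.

Going by these compounds, the true distance between these compounds stays open. So does whether an amine or a carboxylic acid at this place on the ring would give a lower number.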